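A few compounds are considered here, and "the series" means these few. Any claim that something is new, unique, unknown or untested is made for them only; others in the source may bear on it.

Measured compounds in a functional assay on MCF7 cells (Homo sapiens) for inhibition, read by MTT assay, with a stated time of 72 h, tested at 10 uM; on this read-out higher numbers stand for more inhibition at the one concentration tested (going by the name of the read-out) and lower numbers for less inhibition:
- compound 1 `CCOC(=O)C1=C(Nc2ccccc2)S/C(=C\c2ccccc2)C1=O`: 23.6%
- compound 2 `CCOC(=O)C1=C(Nc2ccccc2)S/C(=C\c2ccc(O)c(O)c2)C1=O`: 38.1%
- compound 3 `CCOC(=O)C1=C(Nc2ccccc2)S/C(=C\c2ccc[nH]2)C1=O`: 18.3%

Compound 3 has the lowest of the three numbers in this assay. Its nearest neighbour is compound 1, separated by a number 5.3 percentage points lower from compound 1 to compound 3 (within the scatter), a gap within the scatter; its furthest is compound 2, separated by a number 19.8 percentage points lower from compound 2 to compound 3 (beyond the scatter), a gap beyond it. The third measured step, a number 14.5 percentage points higher from compound 1 to compound 2 (beyond the scatter), is also beyond the scatter.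

Compound 4 `CCOC(=O)C1=C(Nc2ccccc2Br)S/C(=C\c2ccc[nH]2)C1=O` differs from compound 3 at a different place from any of these steps: bromo in place of hydrogen on an aromatic carbon. Within the data shown here, all three measured steps change the group on the double-bonded chain carbon, none touches the anilino phenyl, so no measured step bears directly on this change. With no step of this kind in the series, the expectation is a step of no more than the scatter in this assay, in either direction, so the expected step is a number 1.7 percentage points higher from compound 3 to compound 4 (within the scatter). Compound 4 is therefore estimated at 20% in this assay, with a range of 6% to 36%.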

Compound 4, a percentage reported as inhibition, at one concentration (the size of the read-out at that concentration, not a potency): 29.4%
Compound 4: the middle estimate sits 9.4 percentage points below what was measured; low and high end bracket the measured number.
By their numbers in this assay, from the lowest: compounds 3, 1, 4 and 2 (each within the scatter of the next, the first and the last beyond it).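

In this assay the anilino phenyl proves to be a position where the read-out can move: the change from phenyl to 2-bromophenyl gives a number 11.1 percentage points higher from compound 3 to compound 4 (beyond the scatter) and is the only step shown at this position, as all the others change the group on the double-bonded chain carbon. The series therefore has two places that respond to substitution, although the second rests on this single pair, which carries 1H-pyrrol-2-yl on the chain carbon. No available evidence bears on why bromo shifts the number here.

Going by these compounds, whether bromo gives a similar step with phenyl or 3,4-dihydroxyphenyl on the chain carbon remains open. Also open, on these data alone, is whether the step is specific to bromo, which chloro, methoxy or an amine on the same aromatic carbon would test.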